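Aryl series at the alpha-1D receptor: agonist read-out

This account rests on a few compounds, and the source may have more. Where it says the series, first, only, none or still open, it means among the compounds named here.

Measured so far in a functional assay on CHO cells for agonist activity at Alpha-1D adrenergic receptor (Homo sapiens), read by FLIPR and calcium flux; on this read-out higher numbers stand for an effect only at larger amounts of compound and lower numbers for an effect already at smaller amounts:
compound 1 `c1ccc(C2Cc3nccn3C2)cc1`: > 10000 nM; 7360 nM; > 10000 nM; > 10000 nM (4 entries)
compound 2 `FC(F)Oc1ccccc1C1Cc2nccn2C1`: "not determined" (no result reported)
compound 3 `COc1ccc(C2CCc3nc[nH]c3C2)cc1`: > 10000 nM

Compound 1 returns mostly limits of the assay rather than numbers, with a single numeric entry among them, (the several entries of compound 1 in this assay, > 10000 nM; 7360 nM; > 10000 nM; > 10000 nM (4 entries)). Compound 3 also returns only a limit of the assay, > 10000 nM. Compound 2 carries no result in this assay at all; of the three values shown, one is a limit and one is an empty entry, (the limit of > 10000 nM in this assay, at which 1 of the 3 values shown sits), so compound 2 cannot be placed against the others by number.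

Compound 4 `Fc1ccccc1C1Cc2nccn2C1` differs from compound 2 in one place: fluoro in place of difluoromethoxy on an aromatic carbon. Among the compounds with values here, with no measured step between compound 2 and compound 4 and no number for compound 2, the size of this step in this assay cannot be taken from the data; given the limits seen for compound 1 and compound 3, no effect beyond the scatter is expected from the change, and a limit rather than a number is the more likely outcome.

Compound 4 is therefore expected to give about 10000 nM in this assay, in the range 3000 nM to 30000 nM.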

Compound 4, half-maximal effective concentration: 301 nM
Compound 4: the middle estimate sits 33-fold (1.52 log units) above what was measured; the measured number lies below the stated range.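

Compound 2 carries no number in this assay, so no step to compound 4 can be read, and nothing shown bears on the result of compound 4. Left open is in this assay how fluoro and difluoromethoxy compare on that aromatic carbon.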